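Working notes: compound 3 to compound 4

The compounds below may be only part of what the source reports. "The series", "measured", "known", "first", "only" and "open" are said of these compounds alone.

For the measured compounds named here, in a functional assay on MDA-MB-231 cells (Homo sapiens) for antiproliferative activity, read by MTT assay, with a stated time of 72 h (on this read-out lower numbers stand for stronger inhibition and higher numbers for weaker inhibition), compound 3 (`C#Cc1ccc(NC(=O)CCc2cccc3c2B(O)OC3)cc1`) gives 6600 nM, the only actual number so far. Compound 1 (`CCNC(=O)CCc1cccc2c1B(O)OC2`) reads > 100000 nM, which is a limit. Compound 2 (`CC(C)(C)NC(=O)CCc1cccc2c1B(O)OC2`) reads > 100000 nM, also a limit. The evidence is therefore thin: the limit of > 100000 nM in this assay, at which 2 of the 3 values shown sit. Going by the values given here, the one measured step is a step that the two limits leave unreadable from compound 1 to compound 2, so it offers no size to carry over.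

Compound 4 (`O=C(CCc1cccc2c1B(O)OC2)Nc1ccc([N+](=O)[O-])cc1`) has nitro in place of ethynyl on an aromatic carbon, para to a large group: nitro in place of ethynyl on an aromatic carbon. Among the compounds with values here, no measured step covers this change, so the expectation rests on compound 3 at 6600 nM alone. A small weakening is expected, with either direction possible: a 1.5-fold higher number from compound 3 to compound 4 (0.18 log units; within the scatter). Compound 4 is estimated at 10000 nM, with an expected range of 2500 nM to 40000 nM.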

Compound 4, half-maximal inhibitory concentration: 36000 nM
Beside the measured number, compound 4's estimate is 3.6-fold (0.56 log units) below it; measured number inside the range.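

For the compounds shown here, the group on this aromatic carbon, para to a large group, clearly matters: nitro in place of ethynyl gives a 5.5-fold higher number from compound 3 to compound 4 (0.74 log units; beyond the scatter), the only step with a readable size. Compound 3 and compound 4 both give actual numbers rather than limits in this assay, so this position carries either group without reaching the limit. No measured property on hand accounts for the step.

As far as these compounds go, whether an amine or a carboxylic acid at this place would read closer to compound 3 or to compound 4 stays open. Two groups alone set no trend.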